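This account rests on a few compounds, and the source may have more. Where it says the series, first, only, none or still open, it means among the compounds named here.

Three close relatives built on one shared core have been tested in a functional assay on cells (T-cell, Mus musculus, strain BALB/c) for inhibition, read by MTT assay, with a stated time of 72 h; a lower number here means a stronger inhibitor, a higher number a weaker inhibitor. Compound 1 `COC(=O)c1cc(F)ccc1OC(=O)COc1cc(O)c2c(=O)cc(-c3ccccc3)oc2c1` gives 6820 nM. Compound 2 `COC(=O)c1cc(O)ccc1OC(=O)COc1cc(O)c2c(=O)cc(-c3ccccc3)oc2c1` gives 29500 nM, and compound 3 `COC(=O)c1cccc(Cl)c1OC(=O)COc1cc(O)c2c(=O)cc(-c3ccccc3)oc2c1` gives 38700 nM, the highest of the three numbers. The steps among them are a 4.3-fold higher number from compound 1 to compound 2 (0.64 log units; beyond the scatter), a 5.7-fold higher number from compound 1 to compound 3 (0.75 log units; beyond the scatter) and a 1.3-fold higher number from compound 2 to compound 3 (0.12 log units; within the scatter). Compound 4 `COC(=O)c1cccc(OC)c1OC(=O)COc1cc(O)c2c(=O)cc(-c3ccccc3)oc2c1` differs from compound 3 in one place: methoxy in place of chloro on an aromatic carbon. For the measured compounds named here, no measured step swaps chloro for methoxy directly; the nearest guide is a 1.3-fold higher number from compound 2 to compound 3 (0.12 log units; within the scatter), an exchange of a similar kind that hardly moved the number. The expected step of a 1.3-fold lower number from compound 3 to compound 4 (0.11 log units; within the scatter) is therefore small, in no clear direction. Compound 4 is estimated at 30000 nM, with a likely range from 12000 nM to 80000 nM.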

Compound 4, half-maximal inhibitory concentration: 36800 nM
Beside the measured number, compound 4's estimate is 1.2-fold (0.09 log units) below it, and the stated range covers the measured number.
By their numbers in this assay, from the lowest: compound 1; then compounds 2, 4 and 3 (each within the scatter of the next).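

In this assay, methoxy in place of chloro on this aromatic carbon, ortho to a large group, gives a 1.1-fold lower number from compound 3 to compound 4 (0.02 log units; within the scatter), so the two groups cannot be told apart here. Methoxy is the bigger group and, unlike chloro, carries a hydrogen-bond acceptor, yet neither difference shows up in the number. Nothing available explains this result. Still open, going by these compounds, is whether an amine or a carboxylic acid on this same carbon would also leave the number unmoved, and whether a longer chain such as ethoxy would.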